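Methoxy on the phenyl ring of compound 3

The source may hold more compounds than are shown below. What is called first, only, known or untested is meant among the compounds shown, and "the series" means these compounds.

Values in a functional assay on MCF7 cells (Homo sapiens) for antiproliferative activity, read by MTT assay, with a stated time of 48 h; on this read-out lower numbers stand for stronger inhibition and higher numbers for weaker inhibition:
compound 1 `COc1ccc(-c2nc(SCC(=O)c3sc(-c4ccccc4)nc3C)nc(N)c2C#N)cc1` gives 27200 nM
compound 2 `COc1ccc(-c2nc(C)c(C(=O)CSc3nc(N)c(C#N)c(-c4ccc(Cl)cc4)n3)s2)cc1` gives 11300 nM
compound 3 `COc1ccc(-c2nc(C)c(C(=O)CSc3nc(N)c(C#N)c(-c4ccccc4)n3)s2)cc1` gives 72100 nM

Of the three numbers, compound 3 holds the highest. Compound 4 `COc1ccc(-c2nc(C)c(C(=O)CSc3nc(N)c(C#N)c(-c4ccc(OC)cc4)n3)s2)cc1` goes from phenyl to 4-methoxyphenyl, with methoxy in place of hydrogen on an aromatic carbon, para to a large group (methoxy in place of hydrogen on an aromatic carbon). Among the compounds with values here, one measured step bears on this ring: a 6.4-fold higher number from compound 2 to compound 3 (0.80 log units; beyond the scatter), with hydrogen in place of chloro. Read backwards, that modest step favours a substituent over hydrogen, but methoxy is a different group and a single pair is thin support. A lower number is therefore expected in this assay, with an expected size of a 2.3-fold lower number from compound 3 to compound 4 (0.35 log units; beyond the scatter), smaller than the chloro step. Compound 4 is estimated at 32000 nM (range 11000 nM to 80000 nM).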

Compound 4, half-maximal inhibitory concentration: 24300 nM
Estimate against measurement, compound 4: 1.3-fold (0.12 log units) above; measured number inside the range.
By their numbers in this assay, from the lowest: compound 2; then compounds 4 and 1 (each within the scatter of the next); then compound 3.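

Methoxy on this ring, para to a large group, also lowers the number relative to hydrogen: in this assay there is a 3.0-fold lower number from compound 3 to compound 4 (0.47 log units; beyond the scatter), so this is no longer a chloro-only effect, although a 2.2-fold higher number from compound 2 to compound 4 (0.33 log units; beyond the scatter) keeps chloro ahead of methoxy. The same exchange on the other phenyl ring gives a 1.1-fold lower number from compound 1 to compound 4 (0.05 log units; within the scatter), within the scatter, so the gain is tied to this ring rather than to methoxy anywhere. No measurement here accounts for either result.

On these data alone, whether an amine or a longer alkoxy chain at this position would go beyond chloro remains open.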